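This account rests on a few compounds, and the source may have more. Where it says the series, first, only, none or still open, it means among the compounds named here.

In a functional assay on MGC-803 cells (Homo sapiens) for antiproliferative activity, read by MTT assay, with a stated time of 48 h (a higher number here means a weaker inhibitor, a lower number a stronger inhibitor), compound 1 (`COc1cc(N(Cc2ccc(C)cc2)C(=O)CSc2nc3ccccc3s2)cc(OC)c1OC`) gives 54200 nM and compound 2 (`COc1cc(CN(C(=O)CSc2nc3ccccc3s2)c2cc(OC)c(OC)c(OC)c2)cc(OC)c1OC`) gives 45700 nM while compound 3 (`COc1cc(N(Cc2ccccc2)C(=O)CSc2nc3ccccc3s2)cc(OC)c1OC`) gives 44300 nM on the same scale. Compound 3 therefore stands level with the other two, as its gaps to both lie within the scatter of repeated measurements.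

The change leading to compound 4 (`COc1ccc(CN(C(=O)CSc2nc3ccccc3s2)c2cc(OC)c(OC)c(OC)c2)cc1OC`) is 3,4-dimethoxyphenyl in place of phenyl on a saturated chain carbon bound to an amide-type nitrogen and, in words, it puts 3,4-dimethoxyphenyl in place of phenyl on a saturated chain carbon bound to an amide-type nitrogen.

Among the compounds with values here, two measured steps touch that same place. Putting phenyl in place of 3,4,5-trimethoxyphenyl gave a very small step (a 1.0-fold lower number from compound 2 to compound 3 (0.01 log units; within the scatter)) and putting 3,4,5-trimethoxyphenyl in place of 4-methylphenyl gave another small one (a 1.2-fold lower number from compound 1 to compound 2 (0.07 log units; within the scatter)) in the same series. A third step, hydrogen in place of methyl on an aromatic carbon, is of like size (a 1.2-fold lower number from compound 1 to compound 3 (0.09 log units; within the scatter)) and also stays within the scatter. None of the three compounds carries the 3,4-dimethoxyphenyl group itself, so this remains an inference.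

No step beyond the scatter is expected in this assay and no direction can be favoured. The expected change is small (a 1.0-fold higher number from compound 3 to compound 4 (0.02 log units; within the scatter)) at this estimate. For compound 4 the estimated value is 46000 nM with a likely range from 26000 nM to 80000 nM around it.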

Compound 4, half-maximal inhibitory concentration: 34100 nM
The estimate for compound 4 lay 1.3-fold (0.13 log units) above the measured number; the range from low to high includes it.
By their numbers in this assay, from the lowest: compounds 4, 3, 2 and 1 (each within the scatter of the next).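

In this assay, the 3,4-dimethoxyphenyl group adds a new substitution pattern on this ring, and it does not separate compound 4 from any of the others: the step from the unsubstituted ring stays small (a 1.3-fold lower number from compound 3 to compound 4 (0.11 log units; within the scatter)), removing the methoxy group that distinguishes the 3,4,5-trimethoxyphenyl ring changes little (a 1.3-fold lower number from compound 2 to compound 4 (0.13 log units; within the scatter)), and even the largest of the new steps stays inside the usual noise (a 1.6-fold lower number from compound 1 to compound 4 (0.20 log units; within the scatter)). This position on the saturated chain carbon bound to the amide-type nitrogen has now carried phenyl, 4-methylphenyl, 3,4-dimethoxyphenyl and 3,4,5-trimethoxyphenyl, and these four compounds show no clear preference among those rings, even though the change from phenyl to 3,4-dimethoxyphenyl brings in two hydrogen-bond acceptors. Nothing available here offers an explanation for this flat result.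

As far as these compounds go, all four rings at this position are benzene rings carrying only methyl or methoxy groups, so it remains open whether an amine or a carboxylic acid on the ring, or a longer chain leading to it, would give a step beyond the scatter. The rest of the shared core is the same in all four compounds, so these results say nothing about changes made there.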